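Thiophene in place of methoxyphenyl: cytotoxicity outlook

The source may hold more compounds than are shown below. What is called first, only, known or untested is meant among the compounds shown, and "the series" means these compounds.

Compound 1 `c1ccc(CCSCc2cnc3ccc(-c4ccccc4)cn23)cc1` gives 4 ug/mL in an ADME assay on HEL cells (Homo sapiens) for cytotoxicity, with a stated time of 3 days; a higher number here means that more compound is tolerated, a lower number that less compound is tolerated. Compound 2 `COc1cccc(-c2cc(C)c3ncc(CSCCc4ccccc4)n3c2)c1` gives 20 ug/mL in this assay, and compound 3 `COc1ccc(-c2cc(C)c3ncc(CSCCc4ccccc4)n3c2)cc1` gives 20 ug/mL in this assay. Compound 3 is level with compound 2, the two together the highest of the three numbers, and the step of no change at the digits printed from compound 2 to compound 3 (within the scatter) lies within the scatter. Among the compounds with values here, compound 1 sits clearly lower, but no single-point step joins it to compound 3, so only its value speaks. Compound 4 `Cc1cc(-c2cccs2)cn2c(CSCCc3ccccc3)cnc12` carries thiophen-2-yl in place of 4-methoxyphenyl on an aromatic carbon. Within the data shown here, no measured step exchanges the aryl group itself; the one step in hand, no change at the digits printed from compound 2 to compound 3 (within the scatter), moves nothing beyond the scatter, so no direction follows from it. The expectation is therefore a step of a 1.3-fold lower number from compound 3 to compound 4 (0.12 log units; within the scatter) that stays within the scatter. Compound 4 is estimated at 15 ug/mL, with a range of 6 ug/mL to 40 ug/mL.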

Compound 4, minimum cytotoxic concentration: 20 ug/mL
Estimate against measurement, compound 4: 1.3-fold (0.12 log units) below; the range from low to high includes it.
By their numbers in this assay, from the lowest: compound 1; then compounds 2, 3 and 4 (each within the scatter of the next).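

In this assay the exchange of the whole aryl group at this position gives no change at the digits printed from compound 3 to compound 4 (within the scatter) and no change at the digits printed from compound 2 to compound 4 (within the scatter) and so goes further than the earlier move of methoxy around the phenyl ring. The printed number holds with a five-membered aromatic ring with 1 hetero atom in place of a six-membered aromatic ring of carbon only, and with 5 heavy atoms in place of 8. No supporting evidence accompanies this result. Going by these compounds, whether a carboxylic acid or a piperidine on this aromatic carbon would keep the same number remains open.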